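This account rests on a few compounds, and the source may have more. Where it says the series, first, only, none or still open, it means among the compounds named here.

Measured compounds:
compound 1, `CCCS(=O)(=O)Nc1ccc(F)c(C(=O)c2n[nH]c3ncc(-c4cccc(F)c4)cc23)c1F` — 8.2%
compound 2, `CCCS(=O)(=O)Nc1ccc(F)c(C(=O)c2n[nH]c3ncc(-c4cccc(C)c4)cc23)c1F` — 15%
compound 3, `CCCS(=O)(=O)Nc1ccc(F)c(C(=O)c2n[nH]c3ncc(-c4cccc(N(C)C)c4)cc23)c1F` — 26%

These three compounds share one core and differ only in the substituted phenyl ring attached to it. In an assay for binding affinity to dual specificity mitogen-activated protein kinase kinase 4 (Homo sapiens), read by KINOMEscan, tested at 100 nM (on this read-out higher numbers stand for a weaker effect at the one concentration tested and lower numbers for a stronger effect), compound 3 stands highest of the three numbers; the step of a number 17.8 percentage points higher from compound 1 to compound 3 (beyond the scatter) and the step of a number 11 percentage points higher from compound 2 to compound 3 (beyond the scatter) are both beyond the scatter, whereas a number 6.8 percentage points higher from compound 1 to compound 2 (within the scatter) lies within it. So among these compounds the dimethylamino-bearing compound 3 shows the weakest effect at the concentration tested.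

Compound 4, `CCCS(=O)(=O)Nc1ccc(F)c(C(=O)c2n[nH]c3ncc(-c4ccc(C(C)C)cc4)cc23)c1F`, has not yet been measured. It differs from compound 3 in one place: 4-isopropylphenyl in place of 3-(dimethylamino)phenyl on an aromatic carbon. Among the compounds with values here, no measured step exactly matches this swap, which changes both the nature and the position of the group on the phenyl ring. Within the data shown here, the steps that bear on it are those leading to compound 3: both show that putting a dimethylamino group on the ring raised the number modestly, so taking it away, for a group with no acceptor such as the methyl in compound 2, is expected to lower the number again. A modest step downwards in this assay, a number 11 percentage points lower from compound 3 to compound 4 (beyond the scatter), is therefore expected. Compound 4 is estimated at 15%, with a range from 4% to 40%.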

Compound 4, a percentage reported as activity, at one concentration (the size of the read-out at that concentration, not a potency): 17%
Compound 4: the middle estimate sits 2 percentage points below what was measured; the range from low to high includes it.
By their numbers in this assay, from the lowest: compounds 1, 2, 4 and 3 (each within the scatter of the next, the first and the last beyond it).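

In this assay, the 4-isopropylphenyl group of compound 4 gives a number 9 percentage points lower from compound 3 to compound 4 (within the scatter), so compound 3 is no longer set apart from every other compound in the series, as it was from compound 1 and compound 2. The other two steps, a number 2 percentage points higher from compound 2 to compound 4 (within the scatter) and a number 8.8 percentage points higher from compound 1 to compound 4 (within the scatter), show that this position accepts 4-isopropylphenyl in place of 3-methylphenyl or 3-fluorophenyl with no change beyond the scatter, even though the group and its place on the phenyl ring both differ. Nothing available here accounts for these numbers.

Since the group and its place on the phenyl ring change together between compound 3 and compound 4, the compounds shown cannot separate the two changes; a phenyl ring carrying isopropyl where compound 3 carries dimethylamino, or dimethylamino where compound 4 carries isopropyl, would do so. Also open, from the compounds shown here alone, is how this position responds to a carboxylic acid, a primary amine or a longer alkyl chain on the phenyl ring.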